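This account rests on a few compounds, and the source may have more. Where it says the series, first, only, none or still open, it means among the compounds named here.

Measured so far:
compound 1 `COc1ccc(C(=O)/C=C/c2cc3ccccc3[nH]c2=O)cc1` gives 3980 nM
compound 2 `O=C(/C=C/c1cc2ccccc2[nH]c1=O)c1ccc(O)cc1` gives 7040 nM

For the measured compounds named here, in a functional assay on SF-295 cells (Homo sapiens) for cytotoxicity, read by sulforhodamine B assay, with a stated time of 24 h (a lower number here means a stronger inhibitor of growth, a higher number a weaker inhibitor of growth), compound 2 stands with the highest of the two numbers; its only measured neighbour is reached by a 1.8-fold higher number from compound 1 to compound 2 (0.25 log units; within the scatter), a step within the scatter. Compound 3 `O=C(/C=C/c1cc2ccccc2[nH]c1=O)c1ccc(Cl)cc1` differs from compound 2 by chloro in place of hydroxy on an aromatic carbon. Going by the values given here, no measured step exchanges hydroxy for chloro, so the only guide is the change at the same aromatic carbon, a 1.8-fold higher number from compound 1 to compound 2 (0.25 log units; within the scatter), which stayed within the scatter. For compound 3 no step beyond the scatter is therefore expected, a 1.4-fold lower number from compound 2 to compound 3 (0.15 log units; within the scatter). Compound 3 is estimated at 5000 nM, in the range 2000 nM to 15000 nM.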

Compound 3, concentration for 50% growth inhibition: 4570 nM
Compound 3: middle estimate off by 1.1-fold (0.04 log units), on the high side, and the stated range covers the measured number.
By their numbers in this assay, from the lowest: compounds 1, 3 and 2 (each within the scatter of the next).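

In this assay, the change from 4-hydroxyphenyl to 4-chlorophenyl gives a 1.5-fold lower number from compound 2 to compound 3 (0.19 log units; within the scatter) and exchanging the methoxy group for chloro gives a 1.1-fold higher number from compound 1 to compound 3 (0.06 log units; within the scatter) at the same aromatic carbon. Hydroxy, methoxy and chloro therefore cannot be told apart at this position, even though chloro has 0 hydrogen-bond donors and 0 hydrogen-bond acceptors where hydroxy has 1 of each. Nothing available gives a reason for this flat reading. On these data alone, whether an amine, a carboxylic acid or a longer chain here would move the number beyond the scatter remains open.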